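Moving the fluorine on the hydrazone ring: compound 2 to compound 4

The source may report more compounds than this note shows. Statements on the series, on what has been measured and on what is new or still open speak of the compounds shown alone.

Measured compounds:
Compound 1, `COc1cc(C2=NN(C(C)=O)C(c3c(Cl)cccc3Cl)O2)cc(OC)c1OC`, gives 15.9% in a functional assay on BGC-823 cells (Homo sapiens) for antiproliferative activity, read by MTT assay, tested at 5 uM; on this read-out lower numbers stand for a weaker effect and higher numbers for a stronger effect at the one concentration tested.
Compound 2, `COc1cc(C(=O)N/N=C/c2cccc(F)c2)cc(OC)c1OC`, gives 44.8% in this assay.
Compound 3, `COc1cc(C(=O)N/N=C/c2cccc(C(F)(F)F)c2)cc(OC)c1OC`, gives 33.8% in this assay.

Among these three numbers compound 2 stands highest; compound 3 is nearest to it, and compound 1 is furthest, both beyond the scatter. Among the compounds with values here, the only single-point change measured is a number 11 percentage points lower from compound 2 to compound 3 (beyond the scatter), where a trifluoromethyl replaces the fluoro on an aromatic carbon.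

Compound 4, `COc1cc(C(=O)N/N=C/c2ccc(F)cc2)cc(OC)c1OC`, has not been measured. It differs from compound 2 in one place: 4-fluorophenyl in place of 3-fluorophenyl on a carbon with a double bond to nitrogen. The two compounds contain the same atoms, joined differently, so nothing is added or removed; only where the fluorine sits on that ring changes.

Within the data shown here, no measured step speaks directly to this move of a fluorine on the ring, since the step from compound 2 to compound 3 exchanges one group for another on the same ring carbon rather than shifting it. Among the measured compounds shown here, with no direct precedent, the expectation is a change within the scatter, as the step of a number 4.8 percentage points lower from compound 2 to compound 4 (within the scatter) expresses. Compound 4 is therefore estimated at 40% in this assay, within a range from 25% to 55%.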

Compound 4, a percentage reported as inhibition, at one concentration (the size of the read-out at that concentration, not a potency): 61.1%
The estimate for compound 4 lay 21.1 percentage points below the measured number; measured number outside the range, above it.
By their numbers in this assay, from the lowest: compound 1; then compound 3; then compound 2; then compound 4.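

Where the fluorine sits on this ring matters in this assay: with the same atoms joined differently, and 4-fluorophenyl in place of 3-fluorophenyl, the result is a number 16.3 percentage points higher from compound 2 to compound 4 (beyond the scatter). Within the data shown here, the only earlier change on this ring swapped one group for another and gave a number 11 percentage points lower from compound 2 to compound 3 (beyond the scatter), so the new step adds something different: moving a fluorine, with nothing added or removed, is enough to shift the number beyond the scatter, and this time upward. Nothing available explains why the 4-fluorophenyl compound reads higher, so the finding remains an observation without a known cause.

Going by these compounds, whether this gain is specific to fluorine stays open, since it is not known how a chlorine, a methoxy group or an amine would behave in place of the fluorine of compound 4. The read-out also comes from a single concentration, so it leaves open how far compound 2 and compound 4 differ in potency across a range of concentrations.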